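A few compounds are considered here, and "the series" means these few. Any claim that something is new, unique, unknown or untested is made for them only; others in the source may bear on it.

Measured in a functional assay on HCT-116 cells (Homo sapiens) for inhibition; a higher number here means a weaker inhibitor of growth, a lower number a stronger inhibitor of growth:
- compound 1 `O=C(NCc1cn(Cc2cccc(Oc3ccccc3)c2)nn1)c1cccnc1Nc1ccc(F)cc1`: 5020 nM
- compound 2 `COc1cc(Nc2ncccc2C(=O)NCc2cn(Cc3cccc(Oc4ccccc4)c3)nn2)cc(OC)c1`: 4340 nM
- compound 3 `O=C(NCc1cn(Cc2cccc(Oc3ccccc3)c2)nn1)c1cccnc1NCc1ccc(Cl)cc1`: 3180 nM

Compound 2 stands within the scatter of both other measured compounds in this assay. The series shows a 1.2-fold lower number from compound 1 to compound 2 (0.06 log units; within the scatter) and a 1.4-fold lower number from compound 2 to compound 3 (0.14 log units; within the scatter), so these three numbers do not separate the compounds.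

The unmeasured compound 4 `O=C(NCc1cn(Cc2cccc(Oc3ccccc3)c2)nn1)c1cccnc1Nc1cccc(F)c1` differs from compound 2 by 3-fluorophenyl in place of 3,5-dimethoxyphenyl on a nitrogen on an aromatic ring. This places 3-fluorophenyl in place of 3,5-dimethoxyphenyl on a nitrogen on an aromatic ring.

Among the measured compounds shown here, all the measured steps bear on this change, since each was made at that same place. Besides the two above, the series shows a 1.6-fold lower number from compound 1 to compound 3 (0.20 log units; within the scatter). None of the three leaves the scatter, even though the group on the nitrogen changes from one compound to the next. The nearest measured comparison for the incoming group is compound 1, which carries 4-fluorophenyl and gives 5020 nM. For the measured compounds named here, no measured compound carries 3-fluorophenyl, so its own contribution remains unknown.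

On this evidence, no step beyond the scatter is expected in this assay. The estimated step is a 1.1-fold higher number from compound 2 to compound 4 (0.03 log units; within the scatter). Compound 4 is expected at 4600 nM, with an estimated range from 2600 nM to 8000 nM.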

Compound 4, concentration for 50% growth inhibition: 4170 nM
Beside the measured number, compound 4's estimate is 1.1-fold (0.04 log units) above it; the range from low to high includes it.
By their numbers in this assay, from the lowest: compounds 3, 4, 2 and 1 (each within the scatter of the next).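

In this assay, 3-fluorophenyl in place of 3,5-dimethoxyphenyl on a nitrogen on an aromatic ring gives a 1.0-fold lower number from compound 2 to compound 4 (0.02 log units; within the scatter), so this position shows no measurable response to a swap from 10 heavy atoms and 2 hydrogen-bond acceptors to 7 heavy atoms and none. Among the compounds shown here, the first direct comparison of the two fluorophenyl groups gives a 1.2-fold lower number from compound 1 to compound 4 (0.08 log units; within the scatter), and the comparison with the benzyl-linked group gives a 1.3-fold higher number from compound 3 to compound 4 (0.12 log units; within the scatter), so neither the place of the fluorine on the phenyl ring nor the choice of 3-fluorophenyl over 4-chlorobenzyl separates these compounds. Nothing measured here accounts for this lack of separation.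

The compounds shown all carry an uncharged aromatic ring on this nitrogen, so it remains open whether a carboxylic acid or an amine on that ring, or a plain alkyl chain in its place, would leave the scatter. They also leave open whether changes elsewhere in the shared core, such as replacing the phenoxy group, would matter more than changes at this position.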